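The compounds below may be only part of what the source reports. "The series", "measured", "known", "first", "only" and "open" are said of these compounds alone.

Values measured so far in a functional assay on HepG2 cells (Homo sapiens) for inhibition, read by MTT assay, with a stated time of 72 h, tested at 50 uM; on this read-out higher numbers stand for more inhibition of growth at the one concentration tested and lower numbers for less inhibition of growth
compound 1 `C=CCc1ccc(OCc2cn(-c3ccc(C#N)cc3)nn2)c(O)c1` gives 12.1%
compound 2 `C=CCc1ccc(OCc2cn(-c3ccccc3CO)nn2)c(O)c1` gives 8.5%

These two numbers lie within the usual scatter of each other, so they cannot be ranked, and compound 2 simply stands alongside compound 1 with little growth inhibition. Compound 3 `C=CCc1ccc(OCc2cn(-c3ccc(Br)cc3)nn2)c(O)c1` has not yet been measured. Its change from compound 2 is 4-bromophenyl in place of 2-(hydroxymethyl)phenyl on an aromatic nitrogen and in words it puts 4-bromophenyl in place of 2-(hydroxymethyl)phenyl on an aromatic nitrogen. Among the compounds with values here, only one measured step swaps a group on that same nitrogen, namely a number 3.6 percentage points lower from compound 1 to compound 2 (within the scatter) and it stayed within the scatter. Within the data shown here, no measured compound carries bromine, so this evidence is thin, and no step beyond the scatter is expected in this assay for this swap. The expected change is a number 2.5 percentage points higher from compound 2 to compound 3 (within the scatter) and it remains an estimate. For compound 3 the estimated value is 11% with an expected range from 3% to 22% for a single measurement.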

Compound 3, percent growth inhibition at one concentration: 9.5%
Estimate against measurement, compound 3: 1.5 percentage points above; the range from low to high includes it.
By their numbers in this assay, from the lowest: compounds 2, 3 and 1 (each within the scatter of the next).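

In this assay, the swap on the aromatic nitrogen gives a number 1 percentage points higher from compound 2 to compound 3 (within the scatter) even though 4-bromophenyl has 0 hydrogen-bond donors and 0 hydrogen-bond acceptors, whereas 2-(hydroxymethyl)phenyl has 1 of each. Changing only the group on the aromatic carbon gives a number 2.6 percentage points lower from compound 1 to compound 3 (within the scatter) and so bromo and cyano cannot be told apart here, which leaves all three substituted phenyl groups on this nitrogen within the scatter of one another. Nothing available explains why these numbers lie so close together.

The compounds shown leave open whether a phenyl carrying an amine or a carboxylic acid would give a number beyond the scatter. They also leave open whether a longer chain in place of the phenyl on this nitrogen would do so.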